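Aryloxypropyl series: halogen pattern on the phenyl ring

This account rests on a few compounds, and the source may have more. Where it says the series, first, only, none or still open, it means among the compounds named here.

Measured compounds:
Compound 1 `NC1=NC2(CCSCC2)N(OCCCOc2ccc(Cl)c(Cl)c2)C(N)=N1` gives 88.4% in an assay on isolated protein for inhibition of Dihydrofolate reductase (Homo sapiens), read by spectrophotometry, using NADPH, with stated times of 5 s and 6 min, tested at 5 uM; a lower number here means a weaker effect, a higher number a stronger effect of the compound at the concentration tested.
Compound 2 `NC1=NC2(CCSCC2)N(OCCCOc2ccc(Br)cc2)C(N)=N1` gives > 90% in this assay; this is a limit of the assay, not a number.
Compound 3 `NC1=NC2(CCSCC2)N(OCCCOc2cccc(Cl)c2Cl)C(N)=N1` gives 83.8% in this assay.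

Compound 3 holds the lower of the two numbers shown, with compound 1 nearest: a number 4.6 percentage points lower from compound 1 to compound 3 (within the scatter), a step within the scatter. The other shown value is a limit (the limit of > 90% in this assay, at which 1 of the 3 values shown sits), and the step of a number at least 6.2 percentage points lower from compound 2 to compound 3 (that floor lies within the scatter) has a floor that also lies within the scatter.

Compound 4 `NC1=NC2(CCSCC2)N(OCCCOc2cccc(Br)c2)C(N)=N1` differs from compound 3 by 3-bromophenyl in place of 2,3-dichlorophenyl on an oxygen on a saturated carbon. Going by the values given here, two measured steps bear on this change. One is the swap from a bromophenyl to a dichlorophenyl, a number at least 6.2 percentage points lower from compound 2 to compound 3 (that floor lies within the scatter), whose size cannot be fixed beyond its floor. The other is the shift of the chlorine pattern on the ring, a number 4.6 percentage points lower from compound 1 to compound 3 (within the scatter), which stayed within the scatter. Neither step gives grounds for a move beyond the scatter, and the bromophenyl in compound 2 sits at the limit, so a modest rise is expected: a number 3.2 percentage points higher from compound 3 to compound 4 (within the scatter).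

Compound 4 is therefore estimated at 87% in this assay, expected between 78% and 93%.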

Compound 4, a percentage reported as inhibition, at one concentration (the size of the read-out at that concentration, not a potency): 84.2%
The estimate for compound 4 lay 2.8 percentage points above the measured number; low and high end bracket the measured number.
By their numbers in this assay, from the lowest: compounds 3, 4 and 1 (each within the scatter of the next). At a limit, above all of these: compound 2.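

At this position, on an oxygen on a saturated carbon, 3-bromophenyl in place of 2,3-dichlorophenyl produces no change that stands out in this assay: a number 0.4 percentage points higher from compound 3 to compound 4 (within the scatter), and 3-bromophenyl in place of 3,4-dichlorophenyl gives a number 4.2 percentage points lower from compound 1 to compound 4 (within the scatter). As far as these compounds go, the two bromophenyl groups can now be set side by side, with a number at least 5.8 percentage points lower from compound 2 to compound 4 (that floor lies within the scatter), so no difference between 3-bromophenyl and 4-bromophenyl can be told from the scatter, and the true size of this step remains unknown beyond its floor. Compound 2 is a limit and not a number: the limit of > 90% in this assay, at which 1 of the 4 values shown sits.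

From the compounds shown here alone, with only bromine and chlorine on the phenyl ring, and with a read-out taken at a single concentration, it remains open whether the halogen pattern matters at all in this assay. Also open, going by these compounds, is how this read-out would respond to an unsubstituted phenyl, a phenyl ring carrying a methoxy group or a nitrile, or a longer chain between the two oxygens.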